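The source may report more compounds than this note shows. Statements on the series, on what has been measured and on what is new or still open speak of the compounds shown alone.

The study brings together two measured compounds and one still to be tested. Compound 1 has the structure `O=C(O)c1[nH]c(-c2ccccc2C(F)(F)F)cc(=O)c1O` and compound 2 the structure `O=C(O)c1[nH]c(-c2ccc(-c3nnn[nH]3)cc2)cc(=O)c1O`. Both were run in an ADME assay on MDCK cells (Canis lupus familiaris) for cytotoxicity, read by MTT assay, with a stated time of 12 h; on this read-out higher numbers stand for lower toxicity in this test and lower numbers for higher toxicity in this test. For compound 1 the reading in this assay is a limit of the assay rather than a number, namely > 800000 nM. For compound 2 the reading in this assay is likewise a limit, > 800000 nM. Where compound 2 stands is therefore plain: it sits at the limit of > 800000 nM in this assay, at which 2 of the 2 values shown sit, together with every other value shown, so nothing separates it from compound 1 on these numbers.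

Compound 3, with the structure `Cc1cc(-c2nnn[nH]2)ccc1-c1cc(=O)c(O)c(C(=O)O)[nH]1`, differs from compound 2 in one place: methyl in place of hydrogen on an aromatic carbon. Within the data shown here, no measured pair shows a step of this kind, so the expectation rests on the two limits alone. Compound 3 is expected to stay at the limit, with a step from compound 2 to compound 3 of a number no higher from compound 2 to compound 3 (the limit leaves the size open), none beyond the scatter. The estimate for compound 3 in this assay is 800000 nM, within the range 400000 nM to 2000000 nM.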

Compound 3, half-maximal cytotoxic concentration: > 800000 nM
Compound 3 gave a limit, no number; the forecaster's own chance of this, stated with the estimate: 85%; the middle value lies on the limit itself.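

No step can be read from compound 2 to compound 3 in this assay, since both readings are limits of the assay and not numbers: the limit of > 800000 nM in this assay, at which 3 of the 3 values shown sit. The compounds shown leave open how toxic any of the three is in this assay, and whether methyl in place of hydrogen on an aromatic carbon makes any difference there.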